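The compounds below may be only part of what the source reports. "The series", "measured", "known", "first", "only" and "open" are said of these compounds alone.

The measured compounds, with their values in a functional assay on XF498 cells (Homo sapiens) for antiproliferative activity, read by MTT assay, with a stated time of 96 h; a lower number here means a stronger inhibitor, a higher number a weaker inhibitor:

Compound 1, `COc1ccc(N2C(=O)NC3(CSC4=C3C(=O)c3ncccc3C4=O)C2=O)cc1`, gives 650 nM.
Compound 2, `O=C1C2=C(C(=O)c3ncccc31)C1(CS2)NC(=O)N(c2ccccc2)C1=O`, gives 1510 nM.
Compound 3, `CC(C)(C)c1ccc(N2C(=O)NC3(CSC4=C3C(=O)c3ncccc3C4=O)C2=O)cc1`, gives 850 nM.

Among these three numbers compound 3 stands second highest. Its nearest neighbour is compound 1: a 1.3-fold higher number from compound 1 to compound 3 (0.12 log units; within the scatter), within the scatter. Its furthest is compound 2: a 1.8-fold lower number from compound 2 to compound 3 (0.25 log units; within the scatter), also within the scatter. Within the data shown here, the one step that reaches beyond the scatter is a 2.3-fold higher number from compound 1 to compound 2 (0.37 log units; beyond the scatter), a modest one.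

Compound 4, `O=C1C2=C(C(=O)c3ncccc31)C1(CS2)NC(=O)N(c2ccncc2)C1=O`, differs from compound 3 in one place: pyridin-4-yl in place of 4-(tert-butyl)phenyl on an amide-type nitrogen in a ring. All three measured steps concern the same position, the aryl group on the amide-type nitrogen in a ring of the shared core, and they bear on this change to that extent. Yet each of them only altered a substituent on a phenyl ring; none exchanged the phenyl ring itself for pyridin-4-yl, so the data give no direct precedent. Since the measured steps were at most modest, compound 4 is expected to stay in the same region, with a step of a 1.3-fold higher number from compound 3 to compound 4 (0.11 log units; within the scatter) in this assay that may not pass the scatter, in either direction. Compound 4 is thus estimated at 1100 nM, in a range from 400 nM to 3000 nM.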

Compound 4, half-maximal inhibitory concentration: 1120 nM
Compound 4: middle estimate off by 1.0-fold (0.01 log units), on the low side; measured number inside the range.
By their numbers in this assay, from the lowest: compounds 1, 3, 4 and 2 (each within the scatter of the next, the first and the last beyond it).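

In this assay, among these compounds, the aryl ring on the amide-type nitrogen was itself exchanged for the first time, and all three resulting steps lie within the scatter (a 1.3-fold higher number from compound 3 to compound 4 (0.12 log units; within the scatter); a 1.3-fold lower number from compound 2 to compound 4 (0.13 log units; within the scatter); a 1.7-fold higher number from compound 1 to compound 4 (0.24 log units; within the scatter)). The earlier compounds shown here varied only a substituent on a phenyl ring, whereas compound 4 shows that this position also accepts pyridin-4-yl, with a ring nitrogen and one counted hydrogen-bond acceptor entering, without a step beyond the scatter from any of the three phenyl compounds, even though compound 1 and compound 2 lie beyond the scatter of each other. No measurement is available that would explain this result.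

The compounds shown leave open whether the position would hold the same region with no aromatic ring on that nitrogen, as with a cyclohexyl group or a butyl chain, or with a carboxylic acid or a dimethylamino group on the phenyl ring. They also leave open whether a methoxy group on the pyridine ring would give a step like the one seen on the phenyl ring.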